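The source may hold more compounds than are shown below. What is called first, only, known or untested is meant among the compounds shown, and "the series" means these compounds.

Measured so far in a functional assay on DU-145 cells (Homo sapiens) for inhibition, read by trypan blue exclusion, with a stated time of 72 h; a higher number here means a weaker inhibitor, a lower number a stronger inhibitor:
compound 1, `Cn1c(=O)c(S(=O)(=O)c2ccc(F)cc2)cc2cnc(Nc3ccc4occc4c3)nc21` — compound 1 gives 5000 nM
compound 2, `Cn1c(=O)c(S(=O)(=O)c2ccc(F)cc2)cc2cnc(Nc3cccc4[nH]ccc34)nc21` — compound 2 gives 750 nM

Among the measured compounds shown here, compound 2 holds the lowest number of the two; the one measured step, a 6.7-fold lower number from compound 1 to compound 2 (0.82 log units; beyond the scatter), separates it from compound 1. Compound 3, `Cn1c(=O)c(S(=O)(=O)c2ccc(F)cc2)cc2cnc(Nc3cnc4[nH]ccc4c3)nc21`, differs from compound 2 by a group of 9 heavy atoms (7 carbon, 2 nitrogen; one five-membered aromatic ring with 1 hetero atom, one six-membered aromatic ring with 1 hetero atom) in place of a group of 9 heavy atoms (8 carbon, 1 nitrogen; one five-membered aromatic ring with 1 hetero atom, one six-membered aromatic ring of carbon only), on a nitrogen on an aromatic ring. The measured step bears on this change only in that it also exchanges the group on a nitrogen on an aromatic ring, and there it moved the number in this assay by a modest, beyond-scatter amount. For the measured compounds named here, it swaps a different pair of groups, so it gives no direct reading of size or direction for the present change, and no other pair in the set speaks to it. The working expectation is therefore a step of a 1.3-fold higher number from compound 2 to compound 3 (0.12 log units; within the scatter), within the scatter. Compound 3 is estimated at 1000 nM, with a range from 300 nM to 3500 nM.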

Compound 3, half-maximal inhibitory concentration: 500 nM
For compound 3 the middle estimate is 2.0-fold (0.30 log units) above the measured one, and the stated range covers the measured number.
By their numbers in this assay, from the lowest: compounds 3 and 2 (each within the scatter of the next); then compound 1.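

In this assay, placing the entering group on the nitrogen in exchange for 1H-indol-4-yl gives a 1.5-fold lower number from compound 2 to compound 3 (0.18 log units; within the scatter), so a hetero atom in the six-membered ring, with the added hydrogen-bond acceptor counted for the entering group, leaves no readable difference at this place. Against the benzofuran-bearing compound the same group gives a 10-fold lower number from compound 1 to compound 3 (1.00 log units; beyond the scatter), so compound 1 stands apart from both compound 2 and compound 3, which cannot be ordered against each other. No measurement is available that explains these numbers.

Open, going by these compounds, is how a plain phenyl or a pyridyl group on the same nitrogen would read in this assay, which would show how much the five-membered ring contributes. Also open, on these data alone, is how the series would respond if an amine or a morpholine replaced the fluorine on the shared core.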